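Three Measured Analogues and One Expected Value

The compounds below may be only part of what the source reports. "The series", "measured", "known", "first", "only" and "open" are said of these compounds alone.

Measured in an assay on CHO cells for displacement of a labelled ligand from adenosine receptor A3 (Homo sapiens), with a stated time of 60 min, tested at 10 uM; on this read-out lower numbers stand for less inhibition and higher numbers for more inhibition at the one concentration tested (going by the name of the read-out):
compound 1 `O[C@@H]1[C@H](O)CS[C@H]1Cn1cnc2c(NCc3cccc(Cl)c3)ncnc21` gives 8.9%
compound 2 `O[C@@H]1[C@H](O)CS[C@H]1Cn1cnc2c(NCc3cccc(Cl)c3)nc(Cl)nc21` gives 13.6%
compound 3 `O[C@@H]1[C@H](O)CS[C@H]1Cn1cnc2c(NCc3cccc(F)c3)nc(Cl)nc21` gives 17.6%

All three share one core and differ in two places. Compound 1 differs from compound 2 by hydrogen in place of chloro on an aromatic carbon; the step is a number 4.7 percentage points lower from compound 2 to compound 1 (within the scatter). Compound 3 differs from compound 2 by fluoro in place of chloro on an aromatic carbon; the step is a number 4 percentage points higher from compound 2 to compound 3 (within the scatter). Compound 3 has the highest of the three numbers, but its gaps to compound 2 and to compound 1 both lie within the scatter, so no order among the three can be claimed.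

Compound 4 `O[C@@H]1[C@H](O)CS[C@H]1Cn1cnc2c(NCc3cccc(F)c3)ncnc21` has not yet been measured in this assay. It differs from compound 3 by hydrogen in place of chloro on an aromatic carbon. This is the same kind of change as from compound 2 to compound 1, with the place differing only in that it is meta to a (3-fluorobenzyl)amino group rather than a (3-chlorobenzyl)amino group. Because a number 4.7 percentage points lower from compound 2 to compound 1 (within the scatter) was small, the expected step for compound 4 is a number 4.6 percentage points lower from compound 3 to compound 4 (within the scatter). Compound 4 is therefore estimated at 13%, between 3% and 23%.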

Compound 4, a percentage reported as inhibition, at one concentration (the size of the read-out at that concentration, not a potency): 8.7%
Estimate against measurement, compound 4: 4.3 percentage points above; measured number inside the range.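

In this assay, hydrogen in place of chloro on the aromatic carbon between two ring nitrogen atoms gives a number 8.9 percentage points lower from compound 3 to compound 4 (within the scatter), and this step can be set beside the same change made with the (3-chlorobenzyl)amino group present: the same change on two cores in this assay, a number 4.7 percentage points lower (within the scatter) from compound 2 to compound 1 and a number 8.9 percentage points lower (within the scatter) from compound 3 to compound 4, 4.2 percentage points apart, within the scatter of two such steps. Fluoro in place of chloro on an aromatic carbon gives a number 0.2 percentage points lower from compound 1 to compound 4 (within the scatter), and this step can likewise be set beside its earlier counterpart: the same change on two cores in this assay, a number 4 percentage points higher (within the scatter) from compound 2 to compound 3 and a number 0.2 percentage points lower (within the scatter) from compound 1 to compound 4, 4.2 percentage points apart, within the scatter of two such steps. Neither change can be told apart between the two cores, but each step lies within the scatter, so the series shows no real effect of either change that could be said to carry over, and it cannot show whether a larger effect would transfer.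

The compounds shown leave open what other groups would do at these two places, since the carbon between two ring nitrogen atoms carries only hydrogen or chloro and the benzyl group only chloro or fluoro. An amine at that carbon, or bromo or a methoxy group on the benzyl group, would test the series further.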